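This account rests on a few compounds, and the source may have more. Where it says the series, first, only, none or still open, it means among the compounds named here.

Measured compounds:
compound 1 `CCCc1nc(-c2ccccc2)c(CNCCN2CCN(c3ccc(Cl)cc3)CC2)o1`, 2820 nM
compound 2 `CCCc1nc(-c2ccccc2)c(CNCCCN2CCN(c3ccc(F)cc3)CC2)o1`, 3210 nM
compound 3 `CCCc1nc(-c2ccccc2)c(CNCCN2CCN(C(c3ccccc3)c3ccccc3)CC2)o1`, 7470 nM

All three were tested in an assay on HEK293 cells for inhibition of Voltage-dependent T-type calcium channel subunit alpha-1G (Homo sapiens), read by patch clamp; on this read-out higher numbers stand for weaker inhibition and lower numbers for stronger inhibition. Compound 2 and compound 1 lie within the scatter of each other, so the two cannot be told apart; compound 3 gives a higher number than compound 2, and that gap is beyond the scatter. Compound 4 `CCCc1nc(-c2ccccc2)c(CNCCCN2CCN(c3cccc(C)c3C)CC2)o1` is not yet measured. It differs from compound 2 in one place: 2,3-dimethylphenyl in place of 4-fluorophenyl on an amine nitrogen in a ring. Within the data shown here, no measured pair shows the effect of this kind of change, so nothing points firmly in either direction. The change from compound 2 to compound 4 is expected to stay within the scatter, as a 1.1-fold lower number from compound 2 to compound 4 (0.03 log units; within the scatter). Compound 4 is therefore expected to give about 3000 nM, with a likely range from 1200 nM to 7500 nM.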

Compound 4, half-maximal inhibitory concentration: 1780 nM
Estimate against measurement, compound 4: 1.7-fold (0.23 log units) above; the range from low to high includes it.
By their numbers in this assay, from the lowest: compounds 4, 1 and 2 (each within the scatter of the next); then compound 3.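

Among these compounds, compound 4 shows the first single change at this position: with 2,3-dimethylphenyl in place of 4-fluorophenyl on an amine nitrogen in a ring, this assay gives a 1.8-fold lower number from compound 2 to compound 4 (0.26 log units; within the scatter) and so no readable difference. This position therefore tolerates losing the fluorine and gaining two methyl groups without a change beyond the scatter. Nothing available here explains the result. From the compounds shown here alone, what an unsubstituted phenyl, a pyridyl ring or a methoxyphenyl group would give at this position remains open.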